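This account rests on a few compounds, and the source may have more. Where it says the series, first, only, none or still open, it means among the compounds named here.

Measured compounds:
Compound 1 `COc1ccccc1N1CCN(CC(=O)N2CCN(c3nnc(-c4ccccc4)c(-c4ccccc4)n3)CC2)CC1`: 444000 nM
Compound 2 `COc1ccc(N2CCN(CC(=O)N3CCN(c4nnc(-c5ccc(C)cc5)c(-c5ccc(C)cc5)n4)CC3)CC2)cc1`: 116000 nM
Compound 3 `O=C(CN1CCN(c2ccccc2)CC1)N1CCN(c2nnc(-c3ccc(Cl)cc3)c(-c3ccc(Cl)cc3)n2)CC1`: > 850000 nM

All three compounds share one core and are tested in an ADME assay on NIH3T3 cells (Mus musculus) for cytotoxicity, read by MTT assay, with a stated time of 24 h; on this read-out lower numbers stand for stronger inhibition and higher numbers for weaker inhibition. In this assay compound 1 gives 444000 nM. Compound 2 gives 116000 nM in this assay. Compound 3 is different: for it the assay reports only > 850000 nM, which is a limit of the assay and not a measured number. Where the three values are put side by side, compound 3 therefore stands at the weak end, and more exactly at the limit of > 850000 nM in this assay, at which 1 of the 3 values shown sits. Within the data shown here, because no two measured compounds differ in only one place, no single step between them can be read off.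

The compound to be measured is compound 4 `O=C(CN1CCN(c2ccc([N+](=O)[O-])cc2)CC1)N1CCN(c2nnc(-c3ccc(Cl)cc3)c(-c3ccc(Cl)cc3)n2)CC1`. It differs from compound 3 by nitro in place of hydrogen on an aromatic carbon. With compound 3 itself reported only as a limit, there is no measured step to compare this change with, and nothing in the shown numbers argues for a large move in either direction. The expected step is an at least 1.2-fold lower number from compound 3 to compound 4 (0.08 log units; that floor lies within the scatter), a shift that is estimated to stay within the usual scatter of this assay. For compound 4 the estimated value is 700000 nM, with an expected range from 200000 nM to 2000000 nM, and a good chance that this assay again reports only a limit.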

Compound 4, half-maximal inhibitory concentration: > 789000 nM
Compound 4 was reported as a limit (the forecaster's own chance of this, stated with the estimate: 60%); middle value at least 1.1-fold (0.05 log units) away from the limit.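

Compound 3 and compound 4 are both reported only as limits in this assay, so no step can be read for the change from hydrogen to nitro. The compounds shown leave open where the actual values of compound 3 and compound 4 lie, and whether nitro in place of hydrogen changes the result at all.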